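A Fourth Methyl Group on the Aromatic Ring of Compound 1

The source may hold more compounds than are shown below. What is called first, only, known or untested is meant among the compounds shown, and "the series" means these compounds.

In a functional assay for antagonist activity at corticotropin-releasing factor receptor 1 (Rattus norvegicus) (on this read-out lower numbers stand for stronger inhibition and higher numbers for weaker inhibition), compound 1 `CCC(C1CC1)n1c(=O)c(C)nc2c(-c3cc(C)c(C)cc3C)ccnc21` gives 5.2 nM, the second highest of three numbers. Compound 3 `CCC(C1CC1)n1c(=O)c(C)nc2c(-c3ccc(C)cc3C)ccnc21` gives 8.8 nM and compound 2 `CCC(COC)n1c(=O)c(C)nc2c(-c3cc(F)c(OC)cc3Cl)ccnc21` gives 2.1 nM. The step shows a 1.7-fold higher number from compound 1 to compound 3 (0.23 log units; within the scatter), a change of hydrogen in place of methyl on an aromatic carbon. Compound 4 `CCC(C1CC1)n1c(=O)c(C)nc2c(-c3cc(C)c(C)c(C)c3C)ccnc21` differs from compound 1 by methyl in place of hydrogen on an aromatic carbon. Among the measured compounds shown here, the only measured step that bears on this change is the one from compound 1 to compound 3, which stayed within the scatter, and it suggests that adding or removing a methyl group on this ring moves the number little. Compound 4 is therefore expected at 5.5 nM, between 2.5 nM and 12 nM. That estimate means a 1.1-fold higher number from compound 1 to compound 4 (0.02 log units; within the scatter), not beyond the scatter.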

Compound 4, half-maximal inhibitory concentration: 340 nM
Compound 4: the middle estimate sits 62-fold (1.79 log units) below what was measured, and the stated range ends below it.
By their numbers in this assay, from the lowest: compound 2; then compounds 1 and 3 (each within the scatter of the next); then compound 4.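

In this assay there is a 65-fold higher number from compound 1 to compound 4 (1.82 log units; beyond the scatter) when methyl replaces hydrogen on the aromatic carbon ortho to two methyl groups, whereas the earlier methyl step, at another carbon of the same ring, stayed within the scatter. The same change can therefore give very different results on this ring, depending on the carbon that carries it. No evidence at hand bears on the reason for this large step. From the compounds shown here alone, whether a smaller or different group on this carbon, such as a hydroxyl group or an amine, would give a similar number remains open.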